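The source may report more compounds than this note shows. Statements on the series, on what has been measured and on what is new or still open speak of the compounds shown alone.

Compound 1, `COc1cc(C2NC(=S)NC(c3ccc(C)cc3)=C2CCC(=O)O)cc(OC)c1OC`, gives 16% in a functional assay on the whole organism (strain Albino) for inhibition, with Rattus norvegicus as the target, with stated times of 1 h and 3 h, at a dose of 20 mg/kg by the oral route; a lower number here means less inhibition, a higher number more inhibition at the dose given (going by the name of the read-out). Compound 2, `O=C(O)CCC1=C(c2ccc(Cl)cc2)NC(=S)NC1c1ccco1`, gives 5.52% in this assay. Compound 3, `O=C(O)CCC1=C(c2ccc(Cl)cc2)NC(=S)NC1c1ccccn1`, gives 5.52% in this assay.

Compound 2 stands level with compound 3, and together the two are the lowest of the three numbers; compound 1 lies higher, beyond the scatter. Compound 4, `O=C(O)CCC1=C(c2ccc(F)cc2)NC(=S)NC1c1ccco1`, differs from compound 2 in one place: fluoro in place of chloro on an aromatic carbon. For the measured compounds named here, the only measured step, no change at the digits printed from compound 2 to compound 3 (within the scatter), replaces a group on a saturated ring carbon and does not touch the halogen, so it says little about this change. Going by the values given here, no measured pair swaps fluoro for chloro. The expected step is therefore small, a number 1.5 percentage points higher from compound 2 to compound 4 (within the scatter), with no change beyond the scatter. Compound 4 is estimated at 7%, within 0% to 18%.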

Compound 4, a percentage reported as inhibition, in the whole organism at one dose (the size of the read-out at that dose, not a potency): 3.68%
Beside the measured number, compound 4's estimate is 3.3 percentage points above it; the measured number falls inside the stated range.
By their numbers in this assay, from the lowest: compounds 4, 2 and 3 (each within the scatter of the next); then compound 1.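

In this assay, for the compounds shown here, the change from 4-chlorophenyl to 4-fluorophenyl gives a number 1.8 percentage points lower from compound 2 to compound 4 (within the scatter) and is the first reading at this place on the aromatic ring. Chloro and fluoro can thus be exchanged here without the number leaving the scatter, and both compounds stay among the low values shown. On these data alone, whether a bromo or a methoxy group at this place would move the number beyond the scatter stays open, as does whether the exchange reads the same with pyridin-2-yl on the saturated ring carbon. Nothing given explains why this exchange leaves the number within the scatter.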